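A Core Ester Swapped on a Carbapenem-Type Plasma Stability Series

The compounds below may be only part of what the source reports. "The series", "measured", "known", "first", "only" and "open" are said of these compounds alone.

Of the compounds shown here, three have been measured in an ADME assay on a cell-free system (plasma, Homo sapiens) for metabolic stability, read by LC-MS, with a stated time of 60 min, at 37 degrees C, tested at 50 uM; a lower number here means that less of the compound is left, a higher number that more of the compound is left. Compound 1 `C[C@@H](O)[C@H]1C(=O)N2C(C(=O)OCOC(=O)OC(C)(C)C)=C(S[C@@H]3CN[C@H](C(=O)Nc4cccc(C(=O)O)c4)C3)[C@H](C)[C@H]12` gives 40%, the lowest of the three numbers. Compound 2 `C[C@@H](O)[C@H]1C(=O)N2C(C(=O)OCOC(=O)OC(C)(C)C)=C(S[C@@H]3CN[C@H](C(=O)Nc4cccc(C(=O)OCOC(=O)OC(C)(C)C)c4)C3)[C@H](C)[C@H]12` gives 67%, and compound 3 `C[C@@H](O)[C@H]1C(=O)N2C(C(=O)OCOC(=O)C3CCCCC3)=C(S[C@@H]3CN[C@H](C(=O)Nc4cccc(C(=O)OCOC(=O)C5CCCCC5)c4)C3)[C@H](C)[C@H]12` gives 60%; both lie beyond the scatter above compound 1. Within the data shown here, the one single-point step available, a number 27 percentage points higher from compound 1 to compound 2 (beyond the scatter), changes an oxygen next to a carbonyl group by adding ((tert-butoxycarbonyl)oxy)methyl in place of hydrogen.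

Compound 4 `C[C@@H](O)[C@H]1C(=O)N2C(C(=O)OCC(F)(F)F)=C(S[C@@H]3CN[C@H](C(=O)Nc4cccc(C(=O)O)c4)C3)[C@H](C)[C@H]12` differs from compound 1 in another way: trifluoromethyl in place of (tert-butoxycarbonyl)oxy on a saturated chain carbon bound to an oxygen next to a carbonyl group. Among the measured compounds shown here, no measured pair alters this group, so the change from compound 1 to compound 2 bears on it only indirectly, as a reminder that changes at an oxygen next to a carbonyl group have moved this assay by a modest amount. Without a closer precedent, the size and direction of the step are uncertain. Compound 4 is expected to give 60%, within a range from 35% to 85%. The expected step is a number 20 percentage points higher from compound 1 to compound 4 (beyond the scatter), an estimate and not a measurement.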

Compound 4, percent of the compound remaining: 80%
Compound 4: the middle estimate sits 20 percentage points below what was measured; low and high end bracket the measured number.
By their numbers in this assay, from the lowest: compound 1; then compounds 3 and 2 (each within the scatter of the next); then compound 4.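

In this assay, among these compounds, the change of (tert-butoxycarbonyl)oxy to trifluoromethyl on a saturated chain carbon bound to an oxygen next to a carbonyl group gives a number 40 percentage points higher from compound 1 to compound 4 (beyond the scatter), the first measured change of this group itself. The result shows that this place alone can move the number by a large amount, with the carboxylic acid of compound 1 left untouched in compound 4. No measurement at hand bears on the reason for this step.

With one replacement at this place, the compounds shown do not separate the loss of (tert-butoxycarbonyl)oxy from the arrival of trifluoromethyl, and an ethyl group or a longer chain there would bear on that question. Also open, going by these compounds, is whether 2,2,2-trifluoroethyl would give a similar step in a compound whose carboxylic acid also carries ((tert-butoxycarbonyl)oxy)methyl.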